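Removing a Methoxy Group from a Pyridyl Biaryl Ether

The compounds below may be only part of what the source reports. "The series", "measured", "known", "first", "only" and "open" are said of these compounds alone.

Compound 1, `N#CN1CC(OCc2ccc(-c3ccccc3)cc2)C1`: 2.8 nM
Compound 2, `N#CN1CC(COCc2ccc(-c3ccccc3)cc2)C1`: 3.4 nM
Compound 3, `COc1ccncc1-c1ccc(COC2CN(C#N)C2)cc1`: 40 nM

Three compounds share a core in which a cyanoazetidine is joined through an ether oxygen to a benzyl group carrying a second aromatic ring. Within the data shown here, in an assay on isolated protein for inhibition of N-acylethanolamine-hydrolyzing acid amidase (Homo sapiens), read by fluorescence, with a stated time of 90 min (a higher number here means a weaker inhibitor, a lower number a stronger inhibitor), compound 1 gives 2.8 nM and compound 2 gives 3.4 nM; the only step so far measured, a 1.2-fold higher number from compound 1 to compound 2 (0.08 log units; within the scatter), lengthens the link by one carbon. Compound 3 stands apart: its outer ring holds a nitrogen and a methoxy group, and in this assay compound 3 gives 40 nM, the highest of the three numbers and beyond the scatter from both others.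

Compound 4, `N#CN1CC(OCc2ccc(-c3cccnc3)cc2)C1`, keeps the ring nitrogen of compound 3 but drops the methoxy group: hydrogen in place of methoxy on an aromatic carbon. Among the measured compounds shown here, no measured step isolates this change; compounds 1 and 3 differ in two places at once, so their values only show that the two changes together cost potency. The best guess is that compound 4 lands between them. The estimate for compound 4 is therefore 10 nM, within 3 nM to 40 nM, expected as a 4.0-fold lower number from compound 3 to compound 4 (0.60 log units; beyond the scatter).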

Compound 4, half-maximal inhibitory concentration: 12 nM
Beside the measured number, compound 4's estimate is 1.2-fold (0.08 log units) below it; measured number inside the range.
By their numbers in this assay, from the lowest: compounds 1 and 2 (each within the scatter of the next); then compound 4; then compound 3.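

In this assay, replacing the methoxy group with hydrogen on the aromatic carbon ortho to a large group and opposite the ring nitrogen gives a 3.3-fold lower number from compound 3 to compound 4 (0.52 log units; beyond the scatter), so the methoxy group at this position carries a cost of its own, beyond the scatter, once the ring nitrogen is held fixed. Compound 4 also supplies the missing single change on the other side: pyridin-3-yl in place of phenyl gives a 4.3-fold higher number from compound 1 to compound 4 (0.63 log units; beyond the scatter), so the ring nitrogen alone also moves the number beyond the scatter, and the gap between the first compound and the methoxy pyridine can now be read as two separate steps rather than one combined change. Nothing measured here explains why either step goes in this direction.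

The compounds shown leave open whether a methoxy group on a plain phenyl ring would cost as much as it does on the pyridine, and whether fluorine, methyl or ethoxy at the same carbon would behave like hydrogen or like methoxy. They also leave open how a pyridin-4-yl or pyridin-2-yl outer ring would compare with pyridin-3-yl, and whether these steps carry over to the longer link.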